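Methoxy on a Terminal Phenyl in Thienopyrimidine Piperazines

A few compounds are considered here, and "the series" means these few. Any claim that something is new, unique, unknown or untested is made for them only; others in the source may bear on it.

Of the compounds shown here, three share a thienopyrimidine-piperazine framework and have been tested in a functional assay on MDA-MB-231 cells (Homo sapiens) for antiproliferative activity, read by MTT assay, with a stated time of 48 h; a lower number here means a stronger inhibitor, a higher number a weaker inhibitor. Compound 1 `C=CS(=O)(=O)N1CCN(c2ncnc3sc(-c4ccccc4)cc23)CC1` carries an unsubstituted phenyl on the thiophene and a vinylsulfonyl group on the piperazine; in this assay compound 1 gives 54200 nM. Compound 2 `C=CS(=O)(=O)N1CCN(c2ncnc3sc(-c4ccc(OC)cc4)cc23)CC1` differs from it by methoxy in place of hydrogen on an aromatic carbon, and in this assay compound 2 gives 29900 nM. The step of a 1.8-fold lower number from compound 1 to compound 2 (0.26 log units; within the scatter) is therefore small and does not rise above the noise of repeated measurement.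

Compound 3 `CN1CCN(c2ccc(-c3cc4c(N5CCN(C(=O)Nc6ccccc6)CC5)ncnc4s3)cc2)CC1` has a different core from compound 1: the piperazine bears a phenylcarbamoyl group and the thiophene carries a phenyl substituted with a methylpiperazine. The difference between the two cores is not broken down here. In this assay compound 3 gives 7590 nM, the lowest number of the three, with both compound 1 and compound 2 standing well higher.

Compound 4 `COc1ccc(NC(=O)N2CCN(c3ncnc4sc(-c5ccc(N6CCN(C)CC6)cc5)cc34)CC2)cc1` is not yet measured. It differs from compound 3 by methoxy in place of hydrogen on an aromatic carbon, the same change as that from compound 1 to compound 2, placed para to a large group in both cases. Since that earlier step stayed within the usual scatter, the author expects compound 4 to stay close to compound 3, with a step of a 1.4-fold lower number from compound 3 to compound 4 (0.14 log units; within the scatter). Compound 4 is thus estimated at 5500 nM in this assay, with a plausible range from 2000 nM to 15000 nM.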

Compound 4, half-maximal inhibitory concentration: 20900 nM
Compound 4: the middle estimate sits 3.8-fold (0.58 log units) below what was measured; the measured number lies above the stated range.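

In this assay, within the data shown here, the change from phenylcarbamoyl to (4-methoxyphenyl)carbamoyl gives a 2.8-fold higher number from compound 3 to compound 4 (0.44 log units; beyond the scatter), so the effect of methoxy in place of hydrogen did not carry over unchanged from the core of compound 1 to the core of compound 3: the same change on two cores in this assay, a 1.8-fold lower number (0.26 log units; within the scatter) from compound 1 to compound 2 and a 2.8-fold higher number (0.44 log units; beyond the scatter) from compound 3 to compound 4, 5.0-fold (0.70 log units) apart, beyond the scatter of two such steps This does not show what sets the two steps apart, as the pairs differ both in the rest of the molecule and in which phenyl takes the methoxy, the one on the thiophene in compound 2 and the one in the phenylcarbamoyl group in compound 4, and the data cannot separate these two differences. With only two pairs in a single assay, it also gives no general rule for the series, only a warning that a step seen on one of these compounds cannot be assumed for the other.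

The compounds shown leave open whether the higher number for compound 4 belongs to methoxy itself or would also come with another group at that place, such as a fluorine, a hydroxyl or an amine. They also leave open how methoxy would act on the phenyl bearing the methylpiperazine, or on a compound that keeps the vinylsulfonyl group while carrying that methylpiperazine.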